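The source may report more compounds than this note shows. Statements on the series, on what has been measured and on what is new or still open speak of the compounds shown alone.

Compound 2 `COc1cc(C#N)cc(-c2ncc3ccc(C)nc3n2)c1` gives 1.2 nM in a functional assay on CHO cells for antagonist activity at metabotropic glutamate receptor 5 (Rattus norvegicus), read by FLIPR and calcium flux; a lower number here means a stronger inhibitor, a higher number a weaker inhibitor. Within the data shown here, of the three compounds measured so far, compound 3 `Cc1ccc2cnc(-c3cc(Cl)cc(Cl)c3)nc2n1` gives 0.72 nM, a number within the scatter of that of compound 2, while compound 1 `Cc1ccc2cnc(-c3cccc(C#N)c3)nc2n1` gives 240 nM, a far higher number. Compound 4 `COc1cc(OC)cc(-c2ncc3ccc(C)nc3n2)c1` differs from compound 2 in one place: methoxy in place of cyano on an aromatic carbon. Among the measured compounds shown here, no measured step removes or replaces a cyano group, so the only step that bears on this ring is a 200-fold lower number from compound 1 to compound 2 (2.30 log units; beyond the scatter), a large gain. Going by these compounds, whether a second methoxy can stand in for the cyano is untested, and some loss is expected. For compound 4 the expected step is a 5.0-fold higher number from compound 2 to compound 4 (0.70 log units; beyond the scatter) in this assay. Compound 4 is therefore expected to give about 6 nM, within a range of 1.5 nM to 40 nM.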

Compound 4, half-maximal inhibitory concentration: 179 nM
For compound 4 the middle estimate is 30-fold (1.47 log units) below the measured one, outside the stated range (above it).
By their numbers in this assay, from the lowest: compounds 3 and 2 (each within the scatter of the next); then compounds 4 and 1 (each within the scatter of the next).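

Putting methoxy in place of cyano gives a 150-fold higher number from compound 2 to compound 4 (2.17 log units; beyond the scatter) in this assay, so this position on the ring is far from indifferent to which group it carries. Cyano and methoxy have the same count of heavy atoms and of hydrogen-bond acceptors, so those counts alone do not separate the two groups here. Nothing measured here explains this loss.

Going by these compounds, whether the loss comes from removing cyano or from adding methoxy remains open. So does whether fluorine, trifluoromethyl or an amine at this place would keep the number close to that of compound 2.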